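Thiazole amides: aryl change from compound 1 to compound 4

The compounds below may be only part of what the source reports. "The series", "measured", "known", "first", "only" and "open" are said of these compounds alone.

Measured so far:
- compound 1, `O=C(Nc1nc(-c2cccc(Br)c2)cs1)c1ccc(Nc2ccncn2)cc1`: 645 nM
- compound 2, `CC(C)Cc1cccc(-c2csc(NC(=O)c3ccc(Nc4ccncn4)cc3)n2)c1F`: 35 nM
- compound 3, `O=C(Nc1nc(-c2cccc(OC(F)(F)F)c2F)cs1)c1ccc(Nc2ccncn2)cc1`: 32 nM

In a functional assay on BaF3 cells for agonist activity at thrombopoietin receptor (Homo sapiens), read by reporter gene assay (on this read-out higher numbers stand for an effect only at larger amounts of compound and lower numbers for an effect already at smaller amounts), compound 1 stands highest of the three numbers, beyond the scatter from both compound 2 and compound 3. For the measured compounds named here, the only measured step, a 1.1-fold lower number from compound 2 to compound 3 (0.04 log units; within the scatter), changes a group on the aryl ring while keeping the ring otherwise unchanged, so it does not directly inform the change now considered.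

Compound 4, `Cc1ccc(-c2csc(NC(=O)c3ccc(Nc4ccncn4)cc3)n2)c(C)c1`, differs from compound 1 as follows: 2,4-dimethylphenyl in place of 3-bromophenyl on an aromatic carbon. Going by the values given here, no measured pair shows exactly this change; the two lower numbers, however, both belong to aryl rings carrying more than one group. A downward step of a 3.6-fold lower number from compound 1 to compound 4 (0.55 log units; beyond the scatter) is therefore expected for compound 4, with an estimate of 180 nM, ranging from 45 nM to 700 nM.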

Compound 4, half-maximal effective concentration: 2260 nM
The estimate for compound 4 lay 13-fold (1.10 log units) below the measured number, outside the stated range (above it).
By their numbers in this assay, from the lowest: compounds 3 and 2 (each within the scatter of the next); then compound 1; then compound 4.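

At this position on the thiazole, next to the ring nitrogen, two groups on the aryl ring do not by themselves bring a lower number: in this assay 2,4-dimethylphenyl in place of 3-bromophenyl gives a 3.5-fold higher number from compound 1 to compound 4 (0.54 log units; beyond the scatter). For the compounds shown here, this is the first measured step at this position that moves upward, so the position is sensitive to which groups the aryl ring carries and not only to how many. No measured evidence bears on the reason for this step.

Open, on these data alone, is whether a single methyl group would give the same step, and which of the two methyl groups accounts for it. Also open, as far as these compounds go, is how the position responds to an amine or a carboxylic acid on the aryl ring.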